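The source may hold more compounds than are shown below. What is called first, only, known or untested is meant among the compounds shown, and "the series" means these compounds.

Measured compounds:
- compound 1, `O=C(Nc1cccc(-n2cc(-c3ccncc3)c(-c3cc(O)cc(Cl)c3)n2)c1)Nc1ccc(Cl)c(C(F)(F)F)c1`: 98%
- compound 2, `O=C(Nc1cccc(-n2cc(-c3ccncc3)c(-c3cc(O)cc(Cl)c3)n2)c1)Nc1ccc(Cl)c(Cl)c1`: 91%

In a functional assay on HT-29 cells (Homo sapiens) for inhibition, read by sulforhodamine B assay, with a stated time of 48 h, tested at 0.01 uM (on this read-out higher numbers stand for a weaker effect at the one concentration tested and lower numbers for a stronger effect), compound 1 gives 98% and stands as the higher of the two numbers, with compound 2 nearest to it; the difference a number 7 percentage points lower from compound 1 to compound 2 (within the scatter) is within the scatter, so the two read-outs are not distinguishable. Within the data shown here, that one step, chloro in place of trifluoromethyl on an aromatic carbon, is the only measured step between the two compounds.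

Compound 3, `COc1cc(Cl)cc(-c2nn(-c3cccc(NC(=O)Nc4ccc(Cl)c(C(F)(F)F)c4)c3)cc2-c2ccncc2)c1`, has not yet been measured in this assay. It differs from compound 1 by methyl in place of hydrogen on an oxygen on an aromatic ring. Among the measured compounds shown here, no measured step touches this oxygen: the single step known, from the urea side of the molecule, changes a different part and was itself within the scatter, so it gives no guidance on the direction or size of a change here. With both measured compounds close together near the top of the read-out, and nothing in the data pointing away from that, the step of a number 3 percentage points lower from compound 1 to compound 3 (within the scatter) is expected to be none beyond the scatter. Compound 3 is therefore estimated at 95%, in a range from 80% to 105%.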

Compound 3, a percentage reported as activity, at one concentration (the size of the read-out at that concentration, not a potency): 101%
Estimate against measurement, compound 3: 6 percentage points below; measured number inside the range.
By their numbers in this assay, from the lowest: compounds 2, 1 and 3 (each within the scatter of the next).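

Among these compounds, compound 3 gives the first measurement at this oxygen: in this assay, going from hydroxy to methoxy, with methyl in place of hydrogen on an oxygen on an aromatic ring, gives a number 3 percentage points higher from compound 1 to compound 3 (within the scatter). The hydrogen on this oxygen can therefore be replaced by methyl without a distinguishable change in the read-out, at this one concentration and with the trifluoromethyl group kept on the urea side of the molecule. Nothing measured for these compounds accounts for this result, and a single step at a single concentration gives no potency for either compound.

The compounds shown leave open how an amine or a carboxylic acid in place of the hydroxy would read, and whether a longer chain on this oxygen, such as ethyl or propyl, would read like methyl. Also open, from the compounds shown here alone, is whether the same methyl change would read alike with chloro in place of trifluoromethyl, as in compound 2, or at a concentration where the read-out lies further from where these compounds stand.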